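Same anilino exchange carried onto the methoxy core

The source may report more compounds than this note shows. Statements on the series, on what has been measured and on what is new or still open speak of the compounds shown alone.

Of the compounds shown here, three have been measured in a functional assay on A549 cells (Homo sapiens) for cytotoxicity, read by MTT assay, with a stated time of 72 h; on this read-out higher numbers stand for weaker inhibition and lower numbers for stronger inhibition. Compound 1 `Cc1ccc(S(=O)(=O)c2nc3ccccc3nc2Nc2cccc(N)c2)cc1` gives 1950 nM. Compound 2 `Cc1ccc(S(=O)(=O)c2nc3ccccc3nc2Nc2ccc(F)cc2)cc1` gives 39200 nM, and compound 3 `COc1ccc(S(=O)(=O)c2nc3ccccc3nc2Nc2cccc(N)c2)cc1` gives 340 nM, the lowest number among the three measured compounds; its nearest neighbour is compound 1 and the furthest is compound 2.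

Two single changes connect these. From compound 1 to compound 3 the core changes by methoxy in place of methyl on an aromatic carbon, and this step reads a 5.7-fold lower number from compound 1 to compound 3 (0.76 log units; beyond the scatter). From compound 1 to compound 2 the change is 4-fluorophenyl in place of 3-aminophenyl on a nitrogen on an aromatic ring, with the step of a 20-fold higher number from compound 1 to compound 2 (1.30 log units; beyond the scatter).

Compound 4 `COc1ccc(S(=O)(=O)c2nc3ccccc3nc2Nc2ccc(F)cc2)cc1` is not yet measured. It differs from compound 3 by 4-fluorophenyl in place of 3-aminophenyl on a nitrogen on an aromatic ring. This is the same change as from compound 1 to compound 2, at the same place, carried onto the core of compound 3 rather than the core of compound 1; the two cores differ by methoxy in place of methyl on an aromatic carbon. Within the data shown here, only one earlier instance of this change exists, so the expectation rests on a single pair. For compound 4 a step of about a 19-fold higher number from compound 3 to compound 4 (1.28 log units; beyond the scatter) is expected in this assay, because the same change gave a 20-fold higher number from compound 1 to compound 2 (1.30 log units; beyond the scatter). Compound 4 is therefore estimated at 6500 nM, with the expected range 2000 nM to 25000 nM.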

Compound 4, half-maximal inhibitory concentration: 1240 nM
Compound 4: middle estimate off by 5.2-fold (0.72 log units), on the high side, and the stated range ends above it.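

In this assay, 4-fluorophenyl in place of 3-aminophenyl again raises the number on the methoxy core, with a 3.6-fold higher number from compound 3 to compound 4 (0.56 log units; beyond the scatter), so the direction of the change carries over from the core of compound 1 but its size does not: the same change on two cores in this assay, a 20-fold higher number (1.30 log units; beyond the scatter) from compound 1 to compound 2 and a 3.6-fold higher number (0.56 log units; beyond the scatter) from compound 3 to compound 4, 5.5-fold (0.74 log units) apart, beyond the scatter of two such steps

Seen from the other side of the same four compounds, methoxy in place of methyl lowers the number with either group on the nitrogen, with a 32-fold lower number from compound 2 to compound 4 (1.50 log units; beyond the scatter), and the size of this step also depends on its partner: the same change on two cores in this assay, a 5.7-fold lower number (0.76 log units; beyond the scatter) from compound 1 to compound 3 and a 32-fold lower number (1.50 log units; beyond the scatter) from compound 2 to compound 4, 5.5-fold (0.74 log units) apart, beyond the scatter of two such steps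

Within this set, neither change behaves as a fixed increment that can simply be added to another core, although the direction held in both instances; the four compounds do not show why the sizes differ, nor whether the direction would hold on any further core.

Still open is which part of the exchange accounts for the steps, as loss of the amine and arrival of the fluorine occur together in every pair shown, and a plain phenyl on the same nitrogen would separate the two. Also open, from the compounds shown here alone, is whether the same dependence appears with other groups in place of methoxy, such as ethoxy or chlorine.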